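Replacing the 4-chlorophenyl of compound 2 with piperidin-1-yl

The compounds below may be only part of what the source reports. "The series", "measured", "known", "first", "only" and "open" are said of these compounds alone.

Of the compounds shown here, two have been read in an ADME assay (liver, Mus musculus) for metabolic stability, using microsomes; on this read-out higher numbers stand for a longer-lived compound and lower numbers for a shorter-lived compound. Compound 1 (`CCc1nc2ccc(Cl)cn2c1C(=O)NCc1ccc(-c2ccc(C#N)cc2)cc1`) gives > 1 h, which is a limit of the assay and not a number. Compound 2 (`CCc1nc2cc(Cl)ccn2c1C(=O)NCc1ccc(-c2ccc(Cl)cc2)cc1`) gives > 1 h, which is likewise a limit and not a number. Compound 2 therefore has no exact position, and the record so far is the limit of > 1 h in this assay, at which 2 of the 2 values shown sit.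

Compound 3 (`CCc1nc2cc(Cl)ccn2c1C(=O)NCc1ccc(N2CCCCC2)cc1`) differs from compound 2 in one group, with piperidin-1-yl in place of 4-chlorophenyl on an aromatic carbon. The exchange sits on a six-membered aromatic ring of carbon only, para to a large group.

Among the compounds with values here, no measured step shows what such an exchange does, so the expectation is a judgement on the structural change alone. A move towards a shorter-lived compound, beyond the usual scatter, is expected in this assay. The estimated size of the move is an at least 1.6-fold lower number from compound 2 to compound 3 (0.22 log units; that floor lies within the scatter). For compound 3 the estimated half-life is 0.6 h, with an expected range from 0.2 h to 1.5 h.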

Compound 3, half-life: 0.0383 h
Compound 3: middle estimate off by 16-fold (1.19 log units), on the high side, and the stated range ends above it.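

This place, on an aromatic carbon of a six-membered aromatic ring of carbon only, para to a large group, is the first in the series shown to give a readable change in this assay: piperidin-1-yl in place of 4-chlorophenyl gives an at least 26-fold lower number from compound 2 to compound 3 (1.41 log units; beyond the scatter). Within the data shown here, compound 3, at 0.0383 h, also supplies the first exact number of the series, so the exchange of one ring for another at this place is enough to give a short half-life. Compound 2 gives > 1 h, which is a limit and not a number, and the step carries only a floor because of where the record stands: the limit of > 1 h in this assay, at which 2 of the 3 values shown sit.

From the compounds shown here alone, whether the change follows from the piperidin-1-yl ring itself or from the loss of 4-chlorophenyl stays open, and a morpholine ring or a plain phenyl at the same place would help to separate the two. Also open, going by these compounds, is whether the same exchange on the core of compound 1, with its nitrile, gives a step of like size.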